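A few compounds are considered here, and "the series" means these few. Any claim that something is new, unique, unknown or untested is made for them only; others in the source may bear on it.

Measured so far:
compound 1 `CC(C(=O)NCc1ccc(C(F)(F)F)nc1NCc1ccc(Cl)cc1)c1ccc(NS(C)(=O)=O)c(F)c1`: 65.7 nM
compound 2 `CC(C(=O)NCc1ccc(C(F)(F)F)nc1N1CCC(Cc2ccc(F)c(F)c2)CC1)c1ccc(NS(C)(=O)=O)c(F)c1`: 0.2 nM

In a functional assay on CHO-K1 cells for antagonist activity at transient receptor potential cation channel subfamily V member 1 (Homo sapiens), read by FLIPR (on this read-out lower numbers stand for stronger inhibition and higher numbers for weaker inhibition), compound 1 gives the higher of the two numbers, and compound 2 sits far below it, a gap well beyond the scatter. Compound 3 `CC(C(=O)NCc1ccc(C(F)(F)F)nc1N1CCCCCCC1)c1ccc(NS(C)(=O)=O)c(F)c1` is not yet measured. It differs from compound 1 by a group of 8 heavy atoms (7 carbon, 1 nitrogen; one eight-membered non-aromatic ring with 1 hetero atom) in place of a group of 9 heavy atoms (7 carbon, 1 nitrogen, 1 chlorine; one six-membered aromatic ring of carbon only), on an aromatic carbon. The change trades a group with a hydrogen-bond donor for a ring amine without one, as in compound 2, so a step toward a lower number is expected. The estimated step of an 11-fold lower number from compound 1 to compound 3 (1.04 log units; beyond the scatter) is taken as sizeable but not as large as the gap to compound 2. Compound 3 is therefore expected to give about 6 nM, in a range from 0.6 nM to 60 nM.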

Compound 3, inhibition constant: 0.7 nM
The estimate for compound 3 lay 8.6-fold (0.93 log units) above the measured number; measured number inside the range.
By their numbers in this assay, from the lowest: compound 2; then compound 3; then compound 1.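

In this assay, replacing (4-chlorobenzyl)amino with the eight-membered ring amine on the aromatic carbon next to the ring nitrogen gives a 94-fold lower number from compound 1 to compound 3 (1.97 log units; beyond the scatter). The entering group has no six-membered aromatic ring and no hydrogen-bond donor, so neither is required at this position for a low number. Nothing measured here explains the size of this step. The ring amine and the loss of the donor arrive together, so their separate contributions stay unresolved. Also open, on these data alone, is how an unsubstituted piperidine or a morpholine would read at this position.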